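Removing the dimethylamino from an alkyne-linked aryl ring

The compounds below may be only part of what the source reports. "The series", "measured", "known", "first", "only" and "open" are said of these compounds alone.

Three compounds sharing one core have been measured in a functional assay on MCF7 cells (Homo sapiens) for inhibition, read by sulforhodamine B assay, with a stated time of 48 h; a lower number here means a stronger inhibitor of growth, a higher number a weaker inhibitor of growth:

compound 1, `COC(=O)c1sc2cc(C#Cc3ccc(OC)cc3)cnc2c1N`, gives 460 nM
compound 2, `COC(=O)c1sc2cc(C#Cc3ccccc3F)cnc2c1N`, gives only a limit of the assay, > 150000 nM
compound 3, `COC(=O)c1sc2cc(C#Cc3ccc(N(C)C)cc3)cnc2c1N`, gives 20600 nM

Compound 3 shows the highest of the two numbers; its nearest neighbour is compound 1, separated by a 45-fold higher number from compound 1 to compound 3 (1.65 log units; beyond the scatter). Compound 2 sits at the limit of > 150000 nM in this assay, at which 1 of the 3 values shown sits. Compound 4, `COC(=O)c1sc2cc(C#Cc3ccccc3)cnc2c1N`, is not yet measured; the change is hydrogen in place of dimethylamino on an aromatic carbon, on the ring para to a large group. Among the compounds with values here, two measured steps bear on this. The step of a 45-fold higher number from compound 1 to compound 3 (1.65 log units; beyond the scatter) shows that swapping a methoxy for a dimethylamino on that ring raises the number a great deal, while an at least 320-fold higher number from compound 1 to compound 2 (2.51 log units; beyond the scatter) shows that swapping the whole methoxyphenyl for a fluorophenyl raises it even further. Compound 4 carries neither group on that ring, so a moderate fall in number, beyond the scatter, is expected: a 4.1-fold lower number from compound 3 to compound 4 (0.61 log units; beyond the scatter). Compound 4 is estimated at 5000 nM, within a range from 800 nM to 40000 nM.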

Compound 4, concentration for 50% growth inhibition: > 150000 nM
Compound 4 gave a limit, no number; the forecaster's own chance of this, stated with the estimate: 15%; at least 30-fold (1.47 log units) between middle value and limit.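

Compound 4 reached only a limit of the assay, not a number, so removing the dimethylamino did not recover growth inhibition: the change gives an at least 7.2-fold higher number from compound 3 to compound 4 (0.86 log units; beyond the scatter). The methoxy comparison points the same way, with an at least 320-fold higher number from compound 1 to compound 4 (2.51 log units; beyond the scatter). Among these compounds, then, the two rings carrying a group at this position, methoxy in compound 1 and dimethylamino in compound 3, both give measured values, while hydrogen there in compound 4 does not, so the weaker dimethylamino still outperforms hydrogen.

From the compounds shown here alone, the step between compound 2 and compound 4 cannot be read, since both stop at the same limit: the limit of > 150000 nM in this assay, at which 2 of the 4 values shown sit. It also remains open whether a smaller group such as hydroxyl or a larger one such as ethoxy at this position would match methoxy.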